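From Methoxycarbonyl to Carboxy in Compound 4

A few compounds are considered here, and "the series" means these few. Any claim that something is new, unique, unknown or untested is made for them only; others in the source may bear on it.

Measured in a functional assay on KB cells (Homo sapiens) for cytotoxicity, read by sulforhodamine B assay, with a stated time of 3 days; on this read-out higher numbers stand for an effect only at larger amounts of compound and lower numbers for an effect already at smaller amounts:
- compound 1 (`Cc1coc(-c2ccc3c(c2O)CCCC3)c1C(=O)O`) gives 50 uM
- compound 2 (`COC(=O)c1c(C)coc1-c1ccc2c(c1OC)CCCC2(C)C`) gives 53.4 uM
- compound 3 (`Cc1coc(-c2ccc3c(c2O)CCCC3(C)C)c1C(=O)O`) gives 4.7 uM

Compound 2 lies within the scatter of compound 1, while compound 3 has a lower number, well beyond the scatter from compound 2. Compound 4 (`COc1c(-c2occ(C)c2C(=O)O)ccc2c1CCCC2(C)C`) has not yet been measured in this assay. It departs from compound 2 by hydrogen in place of methyl on an oxygen next to a carbonyl group, which is hydrogen in place of methyl on an oxygen next to a carbonyl group. Among the compounds with values here, no measured pair shows this change alone. Both carboxy compounds offer guidance, compound 3 at 4.7 uM and compound 1 at 50 uM, so only a moderate fall in the number is expected. The expected change is a 3.0-fold lower number from compound 2 to compound 4 (0.47 log units; beyond the scatter). The estimated value for compound 4 is 18 uM, with an expected range of 5 uM to 60 uM.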

Compound 4, concentration for half-maximal effect: 43.3 uM
Beside the measured number, compound 4's estimate is 2.4-fold (0.38 log units) below it; measured number inside the range.
By their numbers in this assay, from the lowest: compound 3; then compounds 4, 1 and 2 (each within the scatter of the next).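

In this assay the change from methoxycarbonyl to carboxy gives a 1.2-fold lower number from compound 2 to compound 4 (0.09 log units; within the scatter), so with the methoxy group kept, this change alone does not move the number beyond the scatter. Methyl in place of hydrogen on an oxygen on an aromatic ring, by contrast, gives a 9.2-fold higher number from compound 3 to compound 4 (0.96 log units; beyond the scatter), so in this pair the larger step lies at that oxygen, not at the oxygen next to a carbonyl group. Nothing available explains either step. The compounds shown leave open how an amide in place of the carboxy group would behave, with either the methoxy or the hydroxy group present.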